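A few compounds are considered here, and "the series" means these few. Any claim that something is new, unique, unknown or untested is made for them only; others in the source may bear on it.

Among the measured compounds shown here, in a functional assay on HCT-116 cells (Homo sapiens), read by MTT assay, with a stated time of 72 h (on this read-out higher numbers stand for weaker inhibition and lower numbers for stronger inhibition), compound 1 (`CSc1ncnc2c1c(-c1ccoc1)cn2[C@@H]1O[C@H](CO)[C@@H](O)[C@H]1O`) gives 100 nM, the only actual number among the values shown. Compound 2 (`CSc1ncnc2c1c(-c1cccs1)cn2[C@@H]1O[C@H](CO)[C@@H](O)[C@H]1O`) reads > 20000 nM, which is a limit of the assay. Compound 3 (`CSc1ncnc2c1c(-c1ccccc1)cn2[C@@H]1O[C@H](CO)[C@@H](O)[C@H]1O`) reads > 20000 nM, which is also a limit. The furan-3-yl group therefore matters greatly here: thiophen-2-yl in its place gives an at least 200-fold higher number from compound 1 to compound 2 (2.30 log units; beyond the scatter), and phenyl in its place gives an at least 200-fold higher number from compound 1 to compound 3 (2.30 log units; beyond the scatter).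

Compound 4 (`Cc1ncnc2c1c(-c1ccoc1)cn2[C@@H]1O[C@H](CO)[C@@H](O)[C@H]1O`) keeps the furan-3-yl group and differs elsewhere on the shared core: methyl in place of methylsulfanyl on an aromatic carbon. For the measured compounds named here, no measured step touches this place, so the large steps above do not transfer directly. They show only how steeply this assay can respond to one substitution. Since compound 4 retains the group present in compound 1 at 100 nM, a moderate change rather than a collapse is expected, with considerable uncertainty. The expected result is a 3.0-fold higher number from compound 1 to compound 4 (0.48 log units; beyond the scatter). For compound 4 the estimated value is 300 nM, with an expected range from 40 nM to 5000 nM.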

Compound 4, half-maximal inhibitory concentration: > 20000 nM
Compound 4: a limit, no number (the forecaster's own chance of this, stated with the estimate: 12%); middle value at least 66-fold (1.82 log units) from the limit.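

Among the compounds shown here, until this result only the furan-3-yl group had been varied, and compound 4 shows that keeping it does not by itself preserve the activity of compound 1: in this assay, methyl in place of methylsulfanyl gives an at least 200-fold higher number from compound 1 to compound 4 (2.30 log units; beyond the scatter). The methylsulfanyl position, on an aromatic carbon next to the ring nitrogen, is therefore also highly sensitive to a single change. Compound 4 gives a limit and not a number, as do compounds 2 and 3, so these three cannot be ordered and the steps among them cannot be read: the limit of > 20000 nM in this assay, at which 3 of the 4 values shown sit.

As far as these compounds go, it remains open whether a methoxy group, an amine or an ethylsulfanyl group at this position would stay close to compound 1 at 100 nM. From the compounds shown here alone, it is equally open whether furan-2-yl or pyridin-3-yl in place of furan-3-yl would give a readable number alongside methylsulfanyl.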